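Ring-nitrogen substituent and metabolic stability on the shared core

The source may hold more compounds than are shown below. What is called first, only, known or untested is meant among the compounds shown, and "the series" means these compounds.

Of the compounds shown here, three have been measured in an ADME assay on S9 fraction from liver (Rattus norvegicus) for metabolic stability, with a stated time of 60 min; on this read-out higher numbers stand for a more stable compound and lower numbers for a less stable compound. Compound 1 `Cc1nc(-c2nc[nH]n2)ccc1-c1cnc2c(n1)N(CCC1CCOCC1)C(=O)CN2` gives 76%. Compound 2 `CO[C@H]1CC[C@@H](CN2C(=O)CNc3ncc(-c4ccc(-c5nc[nH]n5)nc4C)nc32)CC1` gives 39%, and compound 3 `CO[C@H]1CC[C@H](CN2C(=O)CNc3ncc(-c4ccc(-c5nc[nH]n5)nc4C)nc32)CC1` gives 100%. The steps of a number 37 percentage points lower from compound 1 to compound 2 (beyond the scatter) and a number 24 percentage points higher from compound 1 to compound 3 (beyond the scatter) move in opposite directions from the same starting point, and the step of a number 61 percentage points higher from compound 2 to compound 3 (beyond the scatter) is the largest of the three; its two compounds differ only in configuration as drawn (the fact that compounds 2 and 3 differ only in the configuration as drawn). Compound 3 therefore stands highest of the three measured numbers in this assay, beyond the scatter to both compound 1 and compound 2.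

Compound 4 `Cc1nc(-c2nc[nH]n2)ccc1-c1cnc2c(n1)N([C@H]1CC[C@H](O)CC1)C(=O)CN2` is not yet measured. Relative to compound 3 the change is 4-hydroxycyclohexyl in place of (4-methoxycyclohexyl)methyl on an amide-type nitrogen in a ring. Among the compounds with values here, the only measured steps at this position are the two from compound 1 and the stereochemical pair, and the latter shows that the configuration of the cyclohexyl ring can swing the read-out a long way. Within the data shown here, the 4-hydroxycyclohexyl group is new to the series, so no close precedent exists; a modest loss from the top value of compound 3 is expected rather than a gain. For compound 4 the estimate in this assay is 72% (range 40% to 100%), meaning an expected step of a number 28 percentage points lower from compound 3 to compound 4 (beyond the scatter).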

Compound 4, percent of the compound remaining: 91%
Estimate against measurement, compound 4: 19 percentage points below; the range from low to high includes it.
By their numbers in this assay, from the lowest: compound 2; then compound 1; then compounds 4 and 3 (each within the scatter of the next).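

In this assay, 4-hydroxycyclohexyl in place of (4-methoxycyclohexyl)methyl on the amide-type nitrogen in a ring gives a number 9 percentage points lower from compound 3 to compound 4 (within the scatter), so compounds 3 and 4 cannot be ranked against each other. The same replacement measured from the other drawn configuration gives a number 52 percentage points higher from compound 2 to compound 4 (beyond the scatter), and 4-hydroxycyclohexyl in place of 2-(oxan-4-yl)ethyl gives a number 15 percentage points higher from compound 1 to compound 4 (beyond the scatter). Within the data shown here, a high read-out at this position is therefore no longer tied to the single substituent of compound 3: it also holds for a group with 1 hydrogen-bond donor where the group that leaves has none, and compound 2 remains the only low compound of the four.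

Compound 4 is shown in one configuration only, so it stays open whether the 4-hydroxycyclohexyl ring is as sensitive to configuration as the one pair that isolates this change, with a number 61 percentage points higher from compound 2 to compound 3 (beyond the scatter): the fact that compounds 2 and 3 differ only in the configuration as drawn. Also open, going by these compounds, is how a 4-aminocyclohexyl or a 4-carboxycyclohexyl group in place of 4-hydroxycyclohexyl would read in this assay.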